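The compounds below may be only part of what the source reports. "The series", "measured", "known", "first", "only" and "open" are said of these compounds alone.

Measured in a functional assay on HCT-116 cells (Homo sapiens) for inhibition, read by MTT assay, with a stated time of 48 h; a higher number here means a weaker inhibitor, a lower number a stronger inhibitor:
- Compound 1 `COc1ccc(-n2c(S)nnc2-c2cc(OC)c(OC)c(OC)c2)cc1`: > 60000 nM
- Compound 2 `COc1ccc(-n2c(SCC(=O)c3ccccc3)nnc2-c2cc(OC)c(OC)c(OC)c2)cc1`: > 60000 nM
- Compound 3 `COc1cc(-c2nnc(S)n2-c2ccc(N(C)C)cc2)cc(OC)c1OC`: > 60000 nM

Among the measured compounds shown here, all three entries are limits and not numbers, so the series so far shows (the limit of > 60000 nM in this assay, at which 3 of the 3 values shown sit).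

Compound 3 offers only its limit as a starting point. Compound 4 `COc1ccc(CSc2nnc(-c3cc(OC)c(OC)c(OC)c3)n2-c2ccc(N(C)C)cc2)cc1` replaces hydrogen with 4-methoxybenzyl on a sulfur: 4-methoxybenzyl in place of hydrogen on a sulfur.

The closest measured change on that sulfur is a step that the two limits leave unreadable from compound 1 to compound 2, with benzoylmethyl in place of hydrogen. The other measured change, a step that the two limits leave unreadable from compound 1 to compound 3, has dimethylamino in place of methoxy on an aromatic carbon. Neither gives a size to carry over, and neither shows any gain in this assay.

The expected change is an at least 2.0-fold lower number from compound 3 to compound 4 (0.30 log units; that floor lies within the scatter), and this estimate leans towards a stronger inhibitor with low confidence. A result that again reports only a limit is about as likely as a number.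

For compound 4 the estimate is 30000 nM, with an expected range of 2000 nM to 100000 nM.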

Compound 4, half-maximal inhibitory concentration: 1150 nM
Beside the measured number, compound 4's estimate is 26-fold (1.42 log units) above it; the measured number lies below the stated range.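

In this assay, among the compounds shown here, the sulfur whose other neighbour is an aromatic carbon gives the first readable change: 4-methoxybenzyl in place of hydrogen there gives an at least 52-fold lower number from compound 3 to compound 4 (1.71 log units; beyond the scatter), with dimethylamino kept on the other aromatic ring. The earlier steps shown here cannot be read, so they offered no sign of a gain at either place. Compound 4 is now the one entry that gives a number and not a limit: the limit of > 60000 nM in this assay, at which 3 of the 4 values shown sit.

It remains open how much of this step depends on the dimethylamino group, as the shown compounds do not pair 4-methoxybenzyl on this sulfur with methoxy in its place. Also open, going by these compounds, is which part of the entering group carries the step, for instance whether plain benzyl, a longer alkyl chain or a carboxylic acid on the sulfur would keep it.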